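The source may hold more compounds than are shown below. What is called first, only, known or untested is meant among the compounds shown, and "the series" means these compounds.

Measured in a functional assay on cells (Endothelial cell, Bos taurus) for antiproliferative activity; on this read-out higher numbers stand for weaker inhibition and lower numbers for stronger inhibition:
- Compound 1 `COc1ccc(/C(F)=C/c2cc(OC)c(OC)c(OC)c2)cc1F`: 610000 nM
- Compound 2 `COc1ccc(/C(F)=C/c2cc(OC)c(OC)c(OC)c2)cc1O`: 26600 nM
- Compound 3 `COc1ccc(/C(F)=C/c2cc(OC)c(OC)c(OC)c2)cc1N`: 111000 nM

Compound 2 has the lowest number of the three, so it is the strongest inhibitor measured so far. Replacing the group on one aromatic carbon gave a 23-fold lower number from compound 1 to compound 2 (1.36 log units; beyond the scatter), while a second replacement gave a 5.5-fold lower number from compound 1 to compound 3 (0.74 log units; beyond the scatter). The remaining comparison is a 4.2-fold higher number from compound 2 to compound 3 (0.62 log units; beyond the scatter).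

Compound 4 `COc1ccc(/C(F)=C\c2cc(OC)c(OC)c(OC)c2)cc1O` is the next to be considered: the two compounds have the same atoms and bonds and differ only in configuration as drawn: 1 of 1 stereo elements differ; a double bond is drawn Z in compound 2 and E in compound 4. A double bond is drawn Z in compound 2 and E in compound 4. For the measured compounds named here, none of the measured steps alters this configuration, so they give no direct size for the change. They show only that a single replacement can move this assay well beyond the scatter. On the structural change alone, a large move towards a lower number is expected, though with wide uncertainty. The estimated step is a 130-fold lower number from compound 2 to compound 4 (2.12 log units; beyond the scatter). Compound 4 is estimated at 200 nM, within an expected range of 10 nM to 10000 nM.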

Compound 4, half-maximal inhibitory concentration: 4700 nM
Estimate against measurement, compound 4: 24-fold (1.37 log units) below; low and high end bracket the measured number.
By their numbers in this assay, from the lowest: compound 4; then compound 2; then compound 3; then compound 1.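

In this assay, the change of the double bond from Z to E gives a 5.7-fold lower number from compound 2 to compound 4 (0.75 log units; beyond the scatter), so configuration alone moves the number beyond the scatter. The earlier steps shown here, all replacements on one aromatic carbon, could not show this, and compound 4 now has the lowest number of the four. This step can be assigned to the double bond alone, with no group entering or leaving: the fact that compounds 2 and 4 differ only in the configuration as drawn.

The compounds shown leave open whether the same change of configuration would also lower the number with fluoro or amino on that aromatic carbon, as only the hydroxy compounds appear in both forms. They also leave open how a chloro group, a methyl group or a carboxylic acid in place of the hydroxy of compound 4 would read in this assay.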